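This account rests on a few compounds, and the source may have more. Where it says the series, first, only, none or still open, it means among the compounds named here.

Measured so far in an ADME assay on HS27 cells (Homo sapiens) for antiproliferative activity, read by MTT assay, with a stated time of 24 h; a higher number here means a weaker inhibitor, a lower number a stronger inhibitor:

- compound 1 `O=C(Nc1ccc(-n2ccc3c(NC(=O)c4ccccc4)ncnc32)cc1)c1ccc(Cl)c(Cl)c1`, which gives 5000 nM
- compound 2 `CC(=O)Nc1ncnc2c1ccn2-c1ccc(NC(=O)Nc2ccc(Cl)c(C(F)(F)F)c2)cc1`, which gives > 10000 nM

Compound 1 gives a numerical reading in this assay. For compound 2 the reading is a limit of this assay and not a number (the limit of > 10000 nM in this assay, at which 1 of the 2 values shown sits). Going by the values given here, the two measured compounds differ in more than one place, so no single step between them is defined; all the two values show is that compound 1 has a number where compound 2 has only a limit.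

Compound 3 `Nc1ncnc2c1ccn2-c1ccc(NC(=O)Nc2ccc(Cl)c(C(F)(F)F)c2)cc1` is the next member. It differs from compound 2 by hydrogen in place of acetyl on a nitrogen on an aromatic ring. With no measured step of this kind in the series, there is no basis for expecting a shift beyond the usual scatter: the step from compound 2 to compound 3 is expected to be small, a step that the limit leaves unreadable from compound 2 to compound 3, with compound 3 most likely staying near or at the limit where compound 2 stands.

Compound 3 is therefore estimated at 12000 nM in this assay, within a range from 4000 nM to 35000 nM, with a real chance that only a limit is reported.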

Compound 3, half-maximal inhibitory concentration: > 10000 nM
Compound 3 was reported as a limit; the forecaster's own chance of this, stated with the estimate: 60%; the middle value does not contradict the limit.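

In this assay compound 3 gives > 10000 nM as a limit and not a number, and with compound 2 also reported as a limit, no step can be read between the two: the limit of > 10000 nM in this assay, at which 2 of the 3 values shown sit. The compounds shown leave open whether the change from acetamido to amino shifts the reading in this assay at all, and in which direction.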